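The compounds below may be only part of what the source reports. "The series", "measured", "known", "first", "only" and "open" are said of these compounds alone.

Compound 1: `CCCCCn1c(N)nc2c(C)cccc21` — 1130 nM
Compound 2: `CCCCCn1c(N)nc2c(F)cccc21` — "not active" (no number reported)

In an assay on HEK293 cells for agonist activity at Toll-like receptor 8 (Homo sapiens), read by reporter gene assay (on this read-out higher numbers stand for an effect only at larger amounts of compound and lower numbers for an effect already at smaller amounts), compound 1 gives 1130 nM. Compound 2 differs from compound 1 only in the group on the shared core, and on this assay compound 2 is recorded as "not active" (no number reported), so no number places it on the scale; it stands only as a compound that produced no measurable effect in this assay.

Compound 3 is `CCCCCn1c(N)nc2c(C(F)(F)F)cccc21`. It is built from compound 2 by one change: trifluoromethyl in place of fluoro on an aromatic carbon. Among the measured compounds shown here, no measured pair shows what such a change does here, so the size of the step can only be guessed. Since compound 2 has no number, a step cannot be stated as a ratio; an effect in this assay is expected for compound 3, but a weak one, with a real chance that again only "not active" is reported. For compound 3 the estimate in this assay is 4000 nM, with a range from 800 nM to 20000 nM.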

Compound 3, half-maximal effective concentration: "not active" (no number reported)
Nothing numeric was reported for compound 3; the estimate stays without a comparison.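

Compound 2 and compound 3 are both recorded as "not active" without a number in this assay, so no step can be read between them. What the compounds shown leave open is whether either would show an effect at some amount, and how the two would then rank. Nothing available explains this result.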